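The compounds below may be only part of what the source reports. "The series", "measured", "known", "first", "only" and "open" are said of these compounds alone.

Compound 1, `Nc1ccc(C(=O)/C=C/c2ccccc2)cc1`, in a functional assay on DLD-1 cells (Homo sapiens) for cytotoxicity, read by resazurin assay, with a stated time of 48 h; a lower number here means that less compound is needed, a higher number that more compound is needed for the effect: 33000 nM.
Compound 2, `O=C(/C=C/c1ccccc1)c1ccc(NC(=O)c2ccccc2)cc1`, in this assay: 46000 nM.
Compound 3, `CC(=O)Nc1ccc(C(=O)/C=C/c2cccc([N+](=O)[O-])c2)cc1`, in this assay: 6300 nM.

Of these three numbers, compound 3 gives the lowest, and its gap to compound 1 and to compound 2 lies beyond the usual scatter of this assay. Compound 4, `O=C(/C=C/c1cccc([N+](=O)[O-])c1)c1ccc(NC(=O)c2ccccc2)cc1`, has not yet been measured. It differs from compound 3 by phenyl in place of methyl on a carbonyl carbon. Among the measured compounds shown here, the one measured step that resembles this change is a 1.4-fold higher number from compound 1 to compound 2 (0.14 log units; within the scatter), where a benzoyl group also arrived at the amide-type nitrogen, on a different core. That step stayed within the scatter, so for compound 4 a similarly small step is expected: a 1.3-fold higher number from compound 3 to compound 4 (0.10 log units; within the scatter). Compound 4 is therefore estimated at 8000 nM, with a range from 3500 nM to 18000 nM.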

Compound 4, half-maximal effective concentration: > 100000 nM
Compound 4: no number, only a limit; the forecaster's own chance of this, stated with the estimate: 5%; middle value at least 12-fold (1.09 log units) from the limit.
By their numbers in this assay, from the lowest: compound 3; then compounds 1 and 2 (each within the scatter of the next). At a limit, above all of these: compound 4.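

Compound 4 carries no number, only a limit of the assay: the limit of > 100000 nM in this assay, at which 1 of the 4 values shown sits.

With the nitro group in place, phenyl instead of methyl on this carbonyl carbon gives an at least 15-fold higher number from compound 3 to compound 4 (1.20 log units; beyond the scatter), so this position does not tolerate every change. Among the benzamido compounds, nitro in place of hydrogen gives an at least 2.1-fold higher number from compound 2 to compound 4 (0.33 log units; beyond the scatter), so the nitro group does not lower the number in every setting.

Still open, on these data alone, is whether a longer chain, such as propanoyl in place of acetyl, keeps the number close to that of compound 3. Also open, as far as these compounds go, is whether an amine or a carboxylic acid on the benzoyl ring of compound 4 would bring back a measurable number.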